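The source may report more compounds than this note shows. Statements on the series, on what has been measured and on what is new or still open speak of the compounds shown alone.

Compound 1 `O=C(O)c1cncc(C2CC2c2ccc(OCc3c(-c4c(Cl)cccc4Cl)noc3C3CC3)cc2Cl)c1` carries a 5-carboxypyridin-3-yl group on the cyclopropane of the shared core. Among the measured compounds shown here, in an assay on isolated protein for agonist activity at Bile acid receptor (Homo sapiens), read by FRET (on this read-out lower numbers stand for an effect already at smaller amounts and higher numbers for an effect only at larger amounts of compound), compound 1 gives 10 nM, the lowest of the two numbers measured so far. For the measured compounds named here, the only other measured compound, compound 2 `O=C(O)CNC(=O)c1ccc(C2CC2c2ccc(OCc3c(-c4c(Cl)cccc4Cl)noc3C3CC3)cc2Cl)cc1`, replaces that group with a glycine-capped benzamide; in this assay compound 2 gives 150 nM, a number well beyond the scatter away from that of compound 1, so the acid-bearing end of the molecule clearly matters on this read-out.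

Compound 3 `O=C(O)c1ccc(C2CC2c2ccc(OCc3c(-c4c(Cl)cccc4Cl)noc3C3CC3)cc2Cl)cn1` has not yet been measured. It keeps every atom of compound 1 and differs only in where the acid sits on the pyridine: 6-carboxypyridin-3-yl in place of 5-carboxypyridin-3-yl on a saturated ring carbon

Going by the values given here, no measured pair mirrors this change, so the size of the step is uncertain. Since compound 1 already gives 10 nM and the acid is retained, compound 3 is expected to stay within the scatter or gain modestly, a step of a 1.3-fold lower number from compound 1 to compound 3 (0.10 log units; within the scatter). Compound 3 is estimated at 8 nM, with a likely range from 2 nM to 40 nM.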

Compound 3, half-maximal effective concentration: 66 nM
Beside the measured number, compound 3's estimate is 8.3-fold (0.92 log units) below it, and the stated range ends below it.
By their numbers in this assay, from the lowest: compound 1; then compound 3; then compound 2.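

With the atoms of the end group unchanged, the arrangement alone counts in this assay: 6-carboxypyridin-3-yl in place of 5-carboxypyridin-3-yl on a saturated ring carbon gives a 6.6-fold higher number from compound 1 to compound 3 (0.82 log units; beyond the scatter) on this read-out. The earlier pair, compound 1 and compound 2, differed in the whole acid-bearing group, so it could not show that a change with the same atoms, joined differently, also moves the number beyond the scatter. Nothing available here accounts for this step.

As far as these compounds go, whether a carboxyphenyl group, with a ring carbon in place of the pyridine nitrogen, would behave like 5-carboxypyridin-3-yl or like 6-carboxypyridin-3-yl remains open. So does the outcome of putting a tetrazole or a primary amide in place of the carboxylic acid on either pyridine.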